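Compound 3 to compound 4: a side-chain swap

This account rests on a few compounds, and the source may have more. Where it says the series, first, only, none or still open, it means among the compounds named here.

Measured so far in a functional assay on MCF7 cells (Homo sapiens) for inhibition, with a stated time of 96 h (a lower number here means a stronger inhibitor, a higher number a weaker inhibitor), are three compounds:
Compound 1 `C[C@H](CO)Nc1nc(Nc2ccc([S+](N)[O-])cc2)ncc1Br` gives 266 nM
Compound 2 `C#CCNc1nc(Nc2ccccc2)ncc1Br` gives 4000 nM
Compound 3 `C[C@@H](O)[C@@H](C)Oc1nc(Nc2ccc([S+](N)[O-])cc2)ncc1Br` gives 48 nM

Compound 3 has the lowest number of the three in this assay and is the strongest inhibitor here, with its steps to both others beyond the scatter. Compound 4 `C[C@@H](O)[C@@H](C)Nc1nc(Nc2ccc([S+](N)[O-])cc2)ncc1Br` differs from it in one place (2-hydroxy-1-methylpropyl)amino in place of 2-hydroxy-1-methylpropoxy on an aromatic carbon and so carries (2-hydroxy-1-methylpropyl)amino in place of 2-hydroxy-1-methylpropoxy on an aromatic carbon, ortho to a bromo group.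

Among the measured compounds shown here, one measured step bears on this change, namely a 5.5-fold lower number from compound 1 to compound 3 (0.74 log units; beyond the scatter) where an oxygen-linked chain replaced an amino-linked one. The chain itself changed in that step too, and the data cannot separate the two changes. A return to an amino link therefore points towards a higher number, probably by a size similar to or smaller than that step. The expected step is a 2.9-fold higher number from compound 3 to compound 4 (0.46 log units; beyond the scatter) in this assay by this estimate. Compound 4 is expected at 140 nM with an estimated range from 50 nM to 400 nM in this measurement.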

Compound 4, half-maximal inhibitory concentration: 30 nM
The estimate for compound 4 lay 4.7-fold (0.67 log units) above the measured number, and the stated range ends above it.
By their numbers in this assay, from the lowest: compounds 4 and 3 (each within the scatter of the next); then compound 1; then compound 2.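

In this assay, swapping the oxygen link for an amino link on this carbon gives a 1.6-fold lower number from compound 3 to compound 4 (0.20 log units; within the scatter), so with this side chain the two links cannot be told apart. The earlier step from compound 1 to compound 3 changed both the link and the chain, whereas keeping the amino link and adding only a methyl to the chain gives an 8.9-fold lower number from compound 1 to compound 4 (0.95 log units; beyond the scatter), a step that is beyond the scatter and therefore ties a clear change to the chain itself. Nothing available explains why this methyl matters.

On these data alone, it remains open whether a sulfur link would fit this position as well as oxygen and nitrogen do. Also unsettled is how a longer chain, or a methoxy group in place of the hydroxyl, would fare on the same core.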